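Dimethyl to dichloro on the hydrazone aryl group

This account rests on a few compounds, and the source may have more. Where it says the series, first, only, none or still open, it means among the compounds named here.

Compound 1 `CC1CCC(=NNc2ccccc2)c2ncc(C(=O)O)c(=O)n21` gives 0.6 umol/kg in a functional assay on the whole organism with Rattus norvegicus as the target; a lower number here means that less compound is needed, a higher number that more compound is needed for the effect.
Compound 2 `CC1CCC(=NNc2ccccc2)c2ncc(C(=O)NO)c(=O)n21` gives only a limit of the assay, > 100 umol/kg.
Compound 3 `Cc1ccc(NN=C2CCC(C)n3c2ncc(C(=O)O)c3=O)cc1C` gives 6.5 umol/kg.

Among the numbers shown, compound 3 stands highest, and its nearest neighbour is compound 1, with an 11-fold higher number from compound 1 to compound 3 (1.03 log units; beyond the scatter) separating the two by 3,4-dimethylphenyl in place of phenyl on an amine nitrogen. Among the measured compounds shown here, the only other step that has been measured is an at least 160-fold higher number from compound 1 to compound 2 (2.22 log units; beyond the scatter), which concerns hydroxyamino in place of hydroxy on a carbonyl carbon and sits at the limit of > 100 umol/kg in this assay, at which 1 of the 3 values shown sits.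

Compound 4 `CC1CCC(=NNc2ccc(Cl)c(Cl)c2)c2ncc(C(=O)O)c(=O)n21` has not yet been measured. It differs from compound 3 by 3,4-dichlorophenyl in place of 3,4-dimethylphenyl on an amine nitrogen. Neither measured step tests this exchange: the step from compound 1 to compound 3 changes an unsubstituted phenyl into a 3,4-disubstituted one, whereas here one 3,4-disubstituted phenyl gives way to another, and the step from compound 1 to compound 2 concerns a different part of the molecule entirely. For the measured compounds named here, with no step that speaks directly to the change, the expectation is for compound 4 to stay close to compound 3, with a 1.1-fold lower number from compound 3 to compound 4 (0.03 log units; within the scatter) lying within the usual scatter. The estimate for compound 4 is therefore 6 umol/kg, with a range from 2 umol/kg to 20 umol/kg.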

Compound 4, dose for 50% inhibition: 0.89 umol/kg
Beside the measured number, compound 4's estimate is 6.7-fold (0.83 log units) above it, and the stated range ends above it.
By their numbers in this assay, from the lowest: compounds 1 and 4 (each within the scatter of the next); then compound 3. At a limit, above all of these: compound 2.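

In this assay, the two 3,4-disubstituted phenyl groups on the amine nitrogen are not interchangeable: the exchange of 3,4-dimethylphenyl for 3,4-dichlorophenyl gives a 7.3-fold lower number from compound 3 to compound 4 (0.86 log units; beyond the scatter) and so separates two groups that have the same count of heavy atoms and a ring of the same kind. Substitution on this phenyl group therefore does not by itself raise the number, since 3,4-dichlorophenyl in place of phenyl gives only a 1.5-fold higher number from compound 1 to compound 4 (0.17 log units; within the scatter) and compound 4 goes against any reading of the earlier dimethyl result as a general penalty for substituents, leaving that penalty tied, among the compounds shown, to the 3,4-dimethylphenyl group of compound 3. No measurement shown offers a cause for the difference between the methyl and chlorine pairs.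

The compounds shown leave open whether a single chlorine or a single methyl group on the phenyl ring would follow the pattern of the pair that contains it. As far as these compounds go, it also remains open where other groups on this ring, such as methoxy or trifluoromethyl, would fall relative to the chlorine and methyl pairs.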